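A few compounds are considered here, and "the series" means these few. Any claim that something is new, unique, unknown or untested is made for them only; others in the source may bear on it.

Measured so far in an ADME assay on microsomes from liver (Homo sapiens) for metabolic stability, read by LC-MS, using NADPH, tested at 5 uM; on this read-out lower numbers stand for a shorter-lived compound and higher numbers for a longer-lived compound:
compound 1, `Cc1cccc(CSc2cc(Cl)c(C)cc2S(=O)(=O)/N=C(\N)n2nccc2-c2ccccc2)c1`, gives 0.232 h
compound 2, `Cc1cc(S(=O)(=O)/N=C(\N)n2nccc2-c2ccccc2)c(SCc2ccc(C(F)(F)F)cc2)cc1Cl`, gives 0.176 h
compound 3, `Cc1ccc(CSc2cc(Cl)c(C)cc2S(=O)(=O)/N=C(\N)n2nccc2-c2ccccc2)cc1`, gives 0.13 h

Compound 3 carries the lowest of the three numbers, but both neighbours lie close: the step of a 1.8-fold lower number from compound 1 to compound 3 (0.25 log units; within the scatter) and the step of a 1.4-fold lower number from compound 2 to compound 3 (0.13 log units; within the scatter) are each within the scatter, so no order can be read among the three. The remaining pair, a 1.3-fold lower number from compound 1 to compound 2 (0.12 log units; within the scatter), is within the scatter as well.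

Compound 4, `Cc1cc(S(=O)(=O)/N=C(\N)n2nccc2-c2ccccc2)c(SCc2ccc(Cl)cc2)cc1Cl`, is not yet measured. Its difference from compound 3 is chloro in place of methyl on an aromatic carbon. Going by the values given here, the steps that bear on this change are those that alter the substituent of the (4-methylbenzyl)sulfanyl group: a 1.4-fold lower number from compound 2 to compound 3 (0.13 log units; within the scatter) exchanges trifluoromethyl for methyl on the aromatic carbon and stays within the scatter, and a 1.8-fold lower number from compound 1 to compound 3 (0.25 log units; within the scatter) turns 3-methylphenyl into 4-methylphenyl, also within the scatter. Nothing among the three measured compounds indicates that a change of this substituent moves the half-life in this assay beyond the scatter, and chloro is another single-atom group of the same kind.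

Compound 4 is therefore expected to remain in the same band, with 0.15 h, between 0.07 h and 0.32 h. The step of a 1.2-fold higher number from compound 3 to compound 4 (0.06 log units; within the scatter) is expected to be no larger than the usual scatter, in either direction.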

Compound 4, half-life: 0.34 h
Estimate against measurement, compound 4: 2.3-fold (0.36 log units) below; measured number above the stated range.
By their numbers in this assay, from the lowest: compounds 3, 2, 1 and 4 (each within the scatter of the next, the first and the last beyond it).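

In this assay, going by these compounds alone, the series now holds a 2.6-fold higher number from compound 3 to compound 4 (0.42 log units; beyond the scatter) and this is the first step in it to pass beyond the scatter, so the substituent on this aromatic carbon, para to a large group, can move the half-life even though the exchange swaps one heavy atom for one heavy atom and the earlier steps at this site showed no such separation. The separation is limited to the pair with the methyl group, since a 1.9-fold higher number from compound 2 to compound 4 (0.29 log units; within the scatter) and a 1.5-fold higher number from compound 1 to compound 4 (0.17 log units; within the scatter) both stay within the scatter, which leaves compound 4 not set apart from the trifluoromethyl compound or from the 3-methylphenyl compound. No measurement at hand accounts for the step from methyl to chloro.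

Where a methoxy group, a nitrile or a carboxylic acid on this same aromatic carbon would fall relative to compound 3 and compound 4 stays open. Within the data shown here, also open is whether the exchange of methyl for chloro gives a step of this size elsewhere in the molecule, such as on the chlorinated ring of the shared core, as this single pair is the only reading of it.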